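A Third Methoxy Group on a Styryl Sulfone

This account rests on a few compounds, and the source may have more. Where it says the series, first, only, none or still open, it means among the compounds named here.

Compound 1 `COc1ccc(CS(=O)(=O)/C=C/c2ccc(OC)c(OC)c2)cc1`: in a functional assay on DU-145 cells (Homo sapiens) for antiproliferative activity, read by trypan blue exclusion (on this read-out higher numbers stand for weaker inhibition and lower numbers for stronger inhibition), compound 1 gives > 20000 nM, which is a limit of the assay and not a number.
Compound 2 `COc1ccc(CS(=O)(=O)/C=C/c2ccc(OC)cc2OC)cc1`: in this assay compound 2 gives > 20000 nM, again a limit of the assay.

Going by the values given here, compound 2 therefore stands at the edge of what the measurement can report, and the only other value shown sits at the same place; as evidence there is just (the limit of > 20000 nM in this assay, at which 2 of the 2 values shown sit). Compound 3 `COc1ccc(CS(=O)(=O)/C=C/c2ccc(OC)c(OC)c2OC)cc1` differs from compound 2 by methoxy in place of hydrogen on an aromatic carbon, a methoxy in place of hydrogen on an aromatic carbon, ortho to two methoxy groups and meta to a large group. Among the compounds with values here, no measured step between any two compounds exists here, so there is no foothold for a direction. Compound 3 is expected to remain at the limit, and the expected step that the limit leaves unreadable from compound 2 to compound 3 is taken as none beyond the scatter. The estimate for compound 3 is 25000 nM, between 5000 nM and 100000 nM.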

Compound 3, half-maximal inhibitory concentration: > 20000 nM
Compound 3: no number, only a limit; the forecaster's own chance of this, stated with the estimate: 70%; the middle value is on the limit's open side.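

Going by these compounds alone, compound 1, compound 2 and compound 3 all stop at the same limit, so no step between compound 3 and either of the others can be read: the limit of > 20000 nM in this assay, at which 3 of the 3 values shown sit.

The compounds shown leave open whether the added methoxy changes inhibition at all in this assay.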